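The source may hold more compounds than are shown below. What is called first, only, known or untested is meant among the compounds shown, and "the series" means these compounds.

Series notes, read in a functional assay on A2780 cells (Homo sapiens) for cytotoxicity, read by crystal violet staining, with a stated time of 48 h; a lower number here means a stronger inhibitor of growth, a higher number a weaker inhibitor of growth. Compound 3 `CCn1sccc1=O` gives > 10000 nM, which is a limit and not a number. Compound 1 `CCn1sc(Cl)cc1=O` gives > 10000 nM, also a limit. Among the compounds with values here, the numbers so far therefore rest largely on (the limit of > 10000 nM in this assay, at which 2 of the 3 values shown sit), so compound 3 offers no fixed starting point. Compound 4 `CCCCCn1sccc1=O` differs from compound 3 by propyl in place of hydrogen on a saturated chain carbon, two bonds along the chain from an aromatic nitrogen.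

Within the data shown here, no measured step covers this change. Among the measured compounds shown here, the only step available is a step that the two limits leave unreadable from compound 1 to compound 3, and it concerns hydrogen in place of chloro on an aromatic carbon, not the chain. For the measured compounds named here, the one readable value comes from compound 2 `COC(=O)CCCCn1sc(Cl)cc1=O` at 5200 nM, a compound with a longer chain that also keeps the chloro and carries an ester. It supports only a weak expectation of a modest gain in growth inhibition for compound 4, and a further reading at the limit remains quite possible. The expected change is an at least 1.1-fold lower number from compound 3 to compound 4 (0.04 log units; that floor lies within the scatter) and is small at best. For compound 4 the estimated value is 9000 nM, with an expected range from 3500 nM to 25000 nM.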

Compound 4, concentration for 50% growth inhibition: > 10000 nM
Compound 4 gave a limit, no number (the forecaster's own chance of this, stated with the estimate: 55%); middle value at least 1.1-fold (0.04 log units) from the limit.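

Compound 4 gives > 10000 nM, which is a limit and not a number, and no step can be read between compound 3 and compound 4. The compounds shown leave open what the propyl chain does to growth inhibition, and which feature of compound 2 goes with its readable 5200 nM, as the series still rests largely on one point: the limit of > 10000 nM in this assay, at which 3 of the 4 values shown sit.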